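The source may hold more compounds than are shown below. What is called first, only, known or untested is meant among the compounds shown, and "the series" means these compounds.

In an ADME assay on HEK-293T cells (Homo sapiens) for cytotoxicity, read by MTT assay, with a stated time of 72 h (on this read-out lower numbers stand for stronger inhibition and higher numbers for weaker inhibition), compound 1 `O=C(Cn1c(-c2ccccc2)cc(-c2ccccc2)c1-c1ccco1)Nc1nc2ccccc2s1` gives < 50000 nM, which is a limit of the assay rather than a number. Compound 2 `CCc1nnc(NC(=O)Cn2c(-c3ccccc3)cc(-c3ccccc3)c2-c2ccco2)s1` likewise gives a limit in this assay, namely < 50000 nM. Compound 3 `O=C(Cn1c(-c2ccc3ccccc3c2)cc(-c2ccccc2)c1-c1ccco1)Nc1nc2ccccc2s1` also gives only a limit in this assay, < 50000 nM. Compound 3 therefore stands among three values that all sit at the limit of < 50000 nM in this assay, at which 3 of the 3 values shown sit, so none of the three can be ordered against another. For the same reason the step that the two limits leave unreadable from compound 1 to compound 2 and the step that the two limits leave unreadable from compound 1 to compound 3 cannot be read in size or direction.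

Compound 4 `CCc1nnc(NC(=O)Cn2c(-c3ccc4ccccc4c3)cc(-c3ccccc3)c2-c2ccco2)s1` differs from compound 3 by 5-ethyl-1,3,4-thiadiazol-2-yl in place of 1,3-benzothiazol-2-yl on an amide-type nitrogen. For the measured compounds named here, the one measured step of the same kind is a step that the two limits leave unreadable from compound 1 to compound 2, and it left nothing readable. On this evidence no step beyond the scatter is expected in this assay, and the step that the limit leaves unreadable from compound 3 to compound 4 is estimated to be small. Compound 4 is expected to give 30000 nM, within the range 10000 nM to 50000 nM, most probably again only as a limit.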

Compound 4, half-maximal inhibitory concentration: < 50000 nM
Compound 4 was reported as a limit (the forecaster's own chance of this, stated with the estimate: 80%); the middle value lies beyond the limit too.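

The steps from compound 3 to compound 4 and from compound 2 to compound 4 cannot be read in this assay, since compound 4 also gives only a limit: the limit of < 50000 nM in this assay, at which 4 of the 4 values shown sit. The compounds shown leave open how these four compounds rank against one another in this assay.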